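The source may hold more compounds than are shown below. What is called first, only, known or untested is meant among the compounds shown, and "the series" means these compounds.

Measured in a functional assay on A549 cells (Homo sapiens) for cytotoxicity, read by MTT assay, with a stated time of 72 h; on this read-out higher numbers stand for weaker inhibition and lower numbers for stronger inhibition:
- compound 1 `O=C(N/N=C/c1cccc(Br)c1)Nc1cc2c(Nc3ccc(F)c(Cl)c3)ncnc2cc1O[C@H]1CCOC1`: 10700 nM
- compound 2 `COc1ccc(/C=N/NC(=O)Nc2cc3c(Nc4ccc(F)c(Cl)c4)ncnc3cc2O[C@H]2CCOC2)cc1`: 33100 nM
- compound 3 `COc1cc2ncnc(Nc3ccc(F)c(Cl)c3)c2cc1NC(=O)N/N=C/c1cccc(Br)c1`: 28100 nM

Compound 3 holds the second highest of the three numbers in this assay, within the scatter of compound 2, and a 2.6-fold higher number from compound 1 to compound 3 (0.42 log units; beyond the scatter) places it clearly on the weaker side of compound 1.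

Next is compound 4 `COc1cc2ncnc(Nc3ccc(F)c(Cl)c3)c2cc1NC(=O)N/N=C/c1cc(OC)c(OC)c(OC)c1`, which carries 3,4,5-trimethoxyphenyl in place of 3-bromophenyl on a carbon with a double bond to nitrogen.

For the measured compounds named here, the nearest precedent is a 3.1-fold higher number from compound 1 to compound 2 (0.49 log units; beyond the scatter) for 4-methoxyphenyl in place of 3-bromophenyl, a modest step on the core of compound 1. The step of a 2.6-fold higher number from compound 1 to compound 3 (0.42 log units; beyond the scatter) changes the other place and only sets the starting point. Going by the values given here, no measured step covers 3,4,5-trimethoxyphenyl itself, and no measured pair shows whether the earlier step carries over to the core of compound 3.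

A small step towards a higher number is therefore expected, estimated as a 1.8-fold higher number from compound 3 to compound 4 (0.25 log units; within the scatter) in this assay.

The estimate for compound 4 is 50000 nM with an expected range of 18000 nM to 120000 nM.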

Compound 4, half-maximal inhibitory concentration: 32100 nM
Estimate against measurement, compound 4: 1.6-fold (0.19 log units) above; the measured number falls inside the stated range.
By their numbers in this assay, from the lowest: compound 1; then compounds 3, 4 and 2 (each within the scatter of the next).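

On the core of compound 3, 3,4,5-trimethoxyphenyl in place of 3-bromophenyl on the carbon with a double bond to nitrogen gives a 1.1-fold higher number from compound 3 to compound 4 (0.06 log units; within the scatter) in this assay, so this replacement leaves the two compounds inseparable despite the larger group and its added hydrogen-bond acceptors. The earlier step with 4-methoxyphenyl on the core of compound 1, a 3.1-fold higher number from compound 1 to compound 2 (0.49 log units; beyond the scatter), did separate its pair, but that comparison differs in both group and core, so the two steps cannot show whether the core or the group accounts for the contrast. No measurement available here offers an explanation for this result.

Still open, from the compounds shown here alone, is how 3,4,5-trimethoxyphenyl behaves on the core of compound 1, and how 4-methoxyphenyl behaves on the core of compound 3. Also open, going by these compounds, is the effect of a ring bearing a carboxylic acid or an amine at this place.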